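The source may hold more compounds than are shown below. What is called first, only, known or untested is meant among the compounds shown, and "the series" means these compounds.

Compound 2 (`CCC(=O)N(c1ccc(Cl)cc1)C1CCCC1N(C)C`) gives > 50 mg/kg in a functional assay on the whole organism for positive allosteric modulation, with Mus musculus as the target (a higher number here means that more compound is needed for the effect, a lower number that less compound is needed), and that value is a limit of the assay, not a number. Compound 3 (`CCC(=O)N(c1ccc(Cl)c(C)c1)C1CCCC1N(C)C`) gives 10 mg/kg in this assay and so has a true reading. Among the compounds with values here, compound 1 (`CCC(=O)N(c1ccc(Cl)c(Cl)c1)C1CCCC1O`) gives 20 mg/kg in this assay but no single-place step ties it to compound 4.

Compound 4 (`CCC(=O)N(c1ccc([N+](=O)[O-])cc1)C1CCCC1N(C)C`) has nitro in place of chloro on an aromatic carbon, para to a large group (nitro in place of chloro on an aromatic carbon). The nearest measured evidence is an at least 5.0-fold lower number from compound 2 to compound 3 (0.69 log units; beyond the scatter) for a methyl in place of hydrogen on an aromatic carbon. That step lies beyond the scatter and shows that one small addition can change the dose needed. It is a different swap, however, and compound 3 keeps its chloro. Within the data shown here, no measured step replaces chloro, so only a modest move toward a lower number is expected, and a result at the same limit would be no surprise. The estimated step is an at least 1.2-fold lower number from compound 2 to compound 4 (0.09 log units; that floor lies within the scatter) and it remains uncertain. The estimated value for compound 4 is 40 mg/kg with 12 mg/kg to 120 mg/kg as the expected range.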

Compound 4, dose for half-maximal effect: 20 mg/kg
Compound 4: middle estimate off by 2.0-fold (0.30 log units), on the high side, within the range that was stated.
By their numbers in this assay, from the lowest: compounds 3, 1 and 4 (each within the scatter of the next). At a limit, above all of these: compound 2.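

Nitro in place of chloro on this aromatic carbon, para to a large group, gives an at least 2.5-fold lower number from compound 2 to compound 4 (0.39 log units; beyond the scatter). Within the data shown here, the earlier step added a methyl and kept the chloro, so this is the first sign that replacing the chloro itself can lower the dose needed. The size of this step is only a floor, because compound 2 stands at a limit of the assay, not at a number: the limit of > 50 mg/kg in this assay, at which 1 of the 4 values shown sits.

From the compounds shown here alone, whether the lower number belongs to nitro in particular stays open, as only chloro and nitro occupy this place here, and a nitrile or an amine there would help to tell. Going by these compounds, it is also open whether nitro at this place and the added methyl of compound 3 would work together in one compound.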